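Thiophene for Phenyl on Two Nucleoside Cores

This account rests on a few compounds, and the source may have more. Where it says the series, first, only, none or still open, it means among the compounds named here.

Measured so far:
compound 1 `COc1ncnc2c1c(-c1cccs1)cn2[C@@H]1O[C@H](CO)[C@@H](O)[C@H]1O`: 440 nM
compound 2 `Nc1nc(N)c2c(-c3ccccc3)cn([C@@H]3O[C@H](CO)[C@@H](O)[C@H]3O)c2n1`: > 20000 nM
compound 3 `COc1ncnc2c1c(-c1ccccc1)cn2[C@@H]1O[C@H](CO)[C@@H](O)[C@H]1O`: > 20000 nM

Compound 3 `COc1ncnc2c1c(-c1ccccc1)cn2[C@@H]1O[C@H](CO)[C@@H](O)[C@H]1O` and compound 1 `COc1ncnc2c1c(-c1cccs1)cn2[C@@H]1O[C@H](CO)[C@@H](O)[C@H]1O` share one core and differ only by thiophen-2-yl in place of phenyl on an aromatic carbon. In a functional assay on HCT-116 cells (Homo sapiens), read by MTT assay, with a stated time of 72 h (on this read-out lower numbers stand for stronger inhibition and higher numbers for weaker inhibition), compound 3 reaches only a limit of the assay, > 20000 nM. Compound 1 gives 440 nM in this assay. The step is an at least 45-fold lower number from compound 3 to compound 1 (1.65 log units; beyond the scatter), and its size is set as a minimum because of the limit of > 20000 nM in this assay, at which 2 of the 3 values shown sit.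

Compound 2 `Nc1nc(N)c2c(-c3ccccc3)cn([C@@H]3O[C@H](CO)[C@@H](O)[C@H]3O)c2n1` carries a different core; how the two cores differ is not broken down here. In this assay compound 2 also reaches only a limit, > 20000 nM.

Compound 4 `Nc1nc(N)c2c(-c3cccs3)cn([C@@H]3O[C@H](CO)[C@@H](O)[C@H]3O)c2n1` is made from compound 2 by thiophen-2-yl in place of phenyl on an aromatic carbon, the same change at the same place as from compound 3 to compound 1. A step of similar direction is expected, an at least 2.5-fold lower number from compound 2 to compound 4 (0.39 log units; beyond the scatter), resting on the step of an at least 45-fold lower number from compound 3 to compound 1 (1.65 log units; beyond the scatter), though the starting value of compound 2 is itself only a limit. Compound 4 is therefore estimated at 8000 nM in this assay, expected to lie between 1500 nM and 40000 nM.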

Compound 4, half-maximal inhibitory concentration: > 20000 nM
Compound 4: only a limit was reported; the forecaster's own chance of this, stated with the estimate: 45%; middle value at least 2.5-fold (0.39 log units) from the limit.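

In this assay compound 4 reaches only a limit, > 20000 nM. Compound 2 also stands at a limit, so no step can be read from compound 2 to compound 4: the limit of > 20000 nM in this assay, at which 3 of the 4 values shown sit.

The compounds shown leave open whether thiophen-2-yl in place of phenyl changes anything on the core of compound 2, as it does on the core of compound 3.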